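This account rests on a few compounds, and the source may have more. Where it says the series, first, only, none or still open, it means among the compounds named here.

Compound 2, `CCOC(=O)CCCCCOc1cccc(CN(C(=O)c2ccc(-c3cccc(Br)c3)cc2)C(C)C)c1`, stands at the edge of what an ADME assay on HepG2 cells (Homo sapiens) for cytotoxicity, read by CellTiter-Glo and resazurin assay, with a stated time of 72 h (on this read-out lower numbers stand for an effect already at smaller amounts and higher numbers for an effect only at larger amounts of compound), can report: in this assay compound 2 gives > 26000 nM, which is a limit rather than a number. Compound 1, `CCOC(=O)CCCCCOc1cccc(CN(C(=O)c2ccc(-c3cccc4ccccc34)cc2)C(C)C)c1`, is no different in kind, since compound 1 gives > 26000 nM, again a limit. Between them lies a step that the two limits leave unreadable from compound 1 to compound 2, so the exchange of one aryl group for another reveals nothing about size. Among the measured compounds shown here, the single point of evidence is the limit of > 26000 nM in this assay, at which 2 of the 2 values shown sit. Compound 3, `CCOC(=O)CCCCCOc1cccc(CN(C(=O)c2ccc(-c3cccc(CC(=O)O)c3)cc2)C(C)C)c1`, carries carboxymethyl in place of bromo on an aromatic carbon. For the measured compounds named here, no measured step bears on a carboxymethyl group, and the one comparison available ends in two limits. Compound 3 is therefore expected to show the step that the limit leaves unreadable from compound 2 to compound 3, none beyond the scatter. The estimate for compound 3 is 30000 nM, within 10000 nM to 100000 nM, with the likeliest outcome that this assay again reports only a limit.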

Compound 3, half-maximal effective concentration: > 26000 nM
Compound 3 ended at the assay's limit; the forecaster's own chance of this, stated with the estimate: 85%; the middle value is on the limit's open side.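

In this assay compound 3 gives > 26000 nM as a limit and not a number. Among the compounds shown here, no step among compound 1, compound 2 and compound 3 can be read from these limits. The compounds shown leave open where any of the three would give a measurable value in this assay and whether the exchanged groups would then differ at all.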